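Ring Size on the Carbonyl and Permeability

This account rests on a few compounds, and the source may have more. Where it says the series, first, only, none or still open, it means among the compounds named here.

For the measured compounds named here, in an ADME assay on MDCKII-LE cells (Canis lupus familiaris) for permeability (on this read-out higher numbers stand for higher permeability and lower numbers for lower permeability), compound 1 `Cc1cnc(NC(=O)c2cc(Oc3cnc(C(=O)N(C)C)cn3)c3cc(C)oc3c2)cn1` gives 22.3 10^-6 cm/s and compound 2 `Cc1cnc(NC(=O)c2cc(Oc3cnc(C(=O)N4CCC4)cn3)c3cc(C)oc3c2)cn1` gives 17.4 10^-6 cm/s, so compound 2 stands within the scatter of compound 1, the only other number available. Compound 3 `Cc1cnc(NC(=O)c2cc(Oc3cnc(C(=O)N4CCCC4)cn3)c3cc(C)oc3c2)cn1` carries pyrrolidin-1-yl in place of azetidin-1-yl on a carbonyl carbon. Going by the values given here, the one measured step bearing on this, at the same place, is a 1.3-fold lower number from compound 1 to compound 2 (0.11 log units; within the scatter). The expected step in this assay is therefore a 1.0-fold higher number from compound 2 to compound 3 (0.01 log units; within the scatter), with none expected beyond the scatter. Compound 3 is estimated at 18 10^-6 cm/s, with an expected range of 10 10^-6 cm/s to 31 10^-6 cm/s.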

Compound 3, apparent permeability: 15.8 10^-6 cm/s
Estimate against measurement, compound 3: 1.1-fold (0.06 log units) above, within the range that was stated.
By their numbers in this assay, from the lowest: compounds 3, 2 and 1 (each within the scatter of the next).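

In this assay there is a 1.1-fold lower number from compound 2 to compound 3 (0.04 log units; within the scatter) and a 1.4-fold lower number from compound 1 to compound 3 (0.15 log units; within the scatter), so dimethylamino, azetidin-1-yl and pyrrolidin-1-yl on this carbonyl carbon cannot be told apart on this read-out. The five-membered ring thus behaves here like both the four-membered ring and the open dimethylamino group. Nothing available accounts for this result.

Going by these compounds, whether piperidin-1-yl or morpholin-4-yl on the same carbonyl carbon would stay within the scatter remains open. So does the outcome for a carboxylic acid at this place.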